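Sulfonamide-bearing phenyl on the shared core of compound 1

The source may report more compounds than this note shows. Statements on the series, on what has been measured and on what is new or still open speak of the compounds shown alone.

This account follows one change on a shared core, judged in an assay for binding affinity to dual specificity mitogen-activated protein kinase kinase 4 (Homo sapiens), read by KINOMEscan, tested at 100 nM; a higher number here means a weaker effect of the compound at the concentration tested, a lower number a stronger effect. Compound 1 `CCCS(=O)(=O)Nc1ccc(F)c(C(=O)c2n[nH]c3ncc(-c4ccccc4N)cc23)c1F` gives 23%, the second highest of three numbers in this assay. Its nearest neighbour is compound 2 `CCCS(=O)(=O)Nc1ccc(F)c(C(=O)c2n[nH]c3ncc(-c4cccc(N(C)C)c4)cc23)c1F`, which gives 26%; the step of a number 3 percentage points higher from compound 1 to compound 2 (within the scatter) lies within the scatter. The furthest is compound 3 `CCCS(=O)(=O)Nc1ccc(F)c(C(=O)c2n[nH]c3ncc(-c4ccc(S(=O)(=O)NC(C)=O)cc4)cc23)c1F`, which gives 0.35%, a number beyond the scatter below compound 1.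

The step to the unmeasured compound 4 `CCCS(=O)(=O)Nc1ccc(F)c(C(=O)c2n[nH]c3ncc(-c4ccc(NS(C)(=O)=O)cc4)cc23)c1F` is 4-(methanesulfonamido)phenyl in place of 2-aminophenyl on an aromatic carbon. Among the measured compounds shown here, only one measured step bears on it directly, the exchange of the pendant phenyl group between compound 1 and compound 2, and that was a number 3 percentage points higher from compound 1 to compound 2 (within the scatter), no change beyond the scatter. For the measured compounds named here, no step to compound 3 is given, but compound 3, whose phenyl also carries a sulfonamide, shows a far lower number than compound 1, and compound 4 carries a sulfonamide on its phenyl too. On that basis a drop beyond the scatter is expected, of about a number 18 percentage points lower from compound 1 to compound 4 (beyond the scatter). Compound 4 is therefore estimated to give 5% in this assay, with a range from 0.3% to 20%.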

Compound 4, a percentage reported as activity, at one concentration (the size of the read-out at that concentration, not a potency): 0.85%
Compound 4: the middle estimate sits 4.2 percentage points above what was measured, and the stated range covers the measured number.
By their numbers in this assay, from the lowest: compounds 3 and 4 (each within the scatter of the next); then compounds 1 and 2 (each within the scatter of the next).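

The change to 4-(methanesulfonamido)phenyl in this assay gives a number 22.2 percentage points lower from compound 1 to compound 4 (beyond the scatter) and, from the other amino-bearing phenyl, a number 25.2 percentage points lower from compound 2 to compound 4 (beyond the scatter), so this position responds to the group it carries, which the earlier exchange between those two amino-bearing phenyl groups had not shown. The step of a number 0.5 percentage points higher from compound 3 to compound 4 (within the scatter) adds that methanesulfonamido and acetylsulfamoyl on the phenyl cannot be told apart in this read-out, so the low number of compound 3 is not confined to a single sulfonyl-bearing group. All four compounds fall into this split, with the two sulfonyl-bearing groups low and the two amino-bearing groups high and none going against it, but nothing available here accounts for it.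

On these data alone, the sulfonyl-bearing groups also differ from the amino-bearing ones in where they sit on the phenyl, so it stays open whether the group itself or its place on the ring sets the number, and a plain amine in place of the methanesulfonamido of compound 4 would separate the two. As far as these compounds go, what a carboxylic acid on the phenyl, or a longer chain on the sulfonyl group, would give at this position also remains open.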